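The source may hold more compounds than are shown below. What is called first, only, known or untested is meant among the compounds shown, and "the series" means these compounds.

Compound 1 `O=C1CC(c2nc(-c3cccc(Cl)c3)no2)CN1c1ccc(Cl)cc1` gives 140 nM in an in vitro functional assay on HEK293-A cells for positive allosteric modulation of metabotropic glutamate receptor 5 (Homo sapiens), read by FLIPR and calcium flux; a lower number here means that less compound is needed, a higher number that more compound is needed for the effect. Compound 3 `O=C1CC(c2nc(-c3cccc(F)c3)no2)CN1c1ccc(Cl)cc1` gives 630 nM in this assay. Compound 2 `Cc1cccc(-c2noc(C3CC(=O)N(c4ccc(Cl)cc4)C3)n2)n1` reaches only a limit of this assay, > 10000 nM.

Compound 1 holds the lowest of the two numbers shown; its nearest neighbour is compound 3, with a 4.5-fold higher number from compound 1 to compound 3 (0.65 log units; beyond the scatter). Compound 2 sits at the limit of > 10000 nM in this assay, at which 1 of the 3 values shown sits. Compound 4 `Cc1ccccc1N1CC(c2nc(-c3cccc(Cl)c3)no2)CC1=O` differs from compound 1 by 2-methylphenyl in place of 4-chlorophenyl on an amide-type nitrogen in a ring. Every measured step, an at least 71-fold higher number from compound 1 to compound 2 (1.85 log units; beyond the scatter) and an at least 15-fold lower number from compound 2 to compound 3 (1.20 log units; beyond the scatter) among them, changes the group on an aromatic carbon, not the group on the amide-type nitrogen, so none bears directly on this change. Compound 4 is therefore expected to stay near compound 1, with a 2.9-fold higher number from compound 1 to compound 4 (0.46 log units; beyond the scatter) close to the scatter. The estimate for compound 4 is 400 nM, between 100 nM and 3000 nM.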

Compound 4, half-maximal effective concentration: > 10000 nM
Compound 4: only a limit was reported (the forecaster's own chance of this, stated with the estimate: 15%); middle value at least 25-fold (1.39 log units) from the limit.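

For the compounds shown here, the group on the amide-type nitrogen, which no earlier step touched, turns out not to be a silent position in this assay: putting 2-methylphenyl in place of 4-chlorophenyl gives an at least 71-fold higher number from compound 1 to compound 4 (1.85 log units; beyond the scatter). From the compounds shown here alone, that step rests on a limit and not on a number, so its true size stays unknown. Compound 4 stands at a limit of the assay: the limit of > 10000 nM in this assay, at which 2 of the 4 values shown sit.

The compounds shown do not separate the loss of the chlorine from the entry of the methyl. Going by these compounds, how a plain phenyl on that nitrogen would behave stays open.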